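Cytotoxicity in HEL cells: the diyne series, cyclopropyl step

The compounds below may be only part of what the source reports. "The series", "measured", "known", "first", "only" and "open" are said of these compounds alone.

Measured so far, in an ADME assay on HEL cells (Homo sapiens) for cytotoxicity, read by microscopy; on this read-out lower numbers stand for higher toxicity in this test and higher numbers for lower toxicity in this test:
- compound 1, `CCCc1ccc(C#CC#Cc2cn([C@H]3C[C@H](O)[C@@H](CO)O3)c(=O)[nH]c2=O)cc1`: 100000 nM
- compound 2, `O=c1[nH]c(=O)n([C@H]2C[C@H](O)[C@@H](CO)O2)cc1C#CC#Cc1ccccn1`: > 20000 nM, a limit of the assay, not a number
- compound 3, `O=c1[nH]c(=O)n([C@H]2C[C@H](O)[C@@H](CO)O2)cc1C#CC#Cc1ccc([N+](=O)[O-])cc1`: 100000 nM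

Compound 3 stands level with compound 1 at the digits shown; the step of no change at the digits printed from compound 1 to compound 3 (within the scatter) lies within the scatter. Because of the limit of > 20000 nM in this assay, at which 1 of the 3 values shown sits, the steps a step that the limit leaves unreadable from compound 1 to compound 2 and a step that the limit leaves unreadable from compound 2 to compound 3 cannot be read for size. Compound 4, `O=c1[nH]c(=O)n([C@H]2C[C@H](O)[C@@H](CO)O2)cc1C#CC#CC1CC1`, remains to be measured in this assay. It differs from compound 3 as follows: cyclopropyl in place of 4-nitrophenyl on a triple-bonded carbon

Within the data shown here, no measured step touches a cyclopropyl; the only readable step, that from compound 1 to compound 3, shows no change. For compound 4 a step of no change at the digits printed from compound 3 to compound 4 (within the scatter) is therefore expected, none beyond the scatter. Compound 4 is estimated at 100000 nM, within 30000 nM to 100000 nM.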

Compound 4, minimum cytotoxic concentration: > 100000 nM
Compound 4: no number, only a limit; the forecaster's own chance of this, stated with the estimate: 40%; the middle value lies on the limit itself.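

In this assay compound 4 gives > 100000 nM, a limit of the assay and not a number. An aromatic ring on the triple-bonded carbon is thus not needed for a read-out this high, with cyclopropyl in its place giving a number no lower from compound 3 to compound 4 (the limit leaves the size open) and a number no lower from compound 1 to compound 4 (the limit leaves the size open). The size of these steps, like that of the step between compound 2 and compound 4, cannot be read: the limit of > 100000 nM in this assay, at which 1 of the 4 values shown sits.

From the compounds shown here alone, how far the true value of compound 4 lies from its limit stays open. So does whether another non-aromatic group on this carbon, such as an aminomethyl group or a longer alkyl chain, reads like cyclopropyl.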